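A few compounds are considered here, and "the series" means these few. Any claim that something is new, unique, unknown or untested is made for them only; others in the source may bear on it.

Measured compounds:
- compound 1, `CCN(CC)CCNC(=O)c1ccc(C(CC)(CC)c2ccc(OCC(O)C(C)(C)C)c(C)c2)n1CC`: in an ADME assay on L02 cells (Homo sapiens) for cytotoxicity, read by MTT assay, with a stated time of 48 h (a lower number here means a stronger inhibitor, a higher number a weaker inhibitor), compound 1 gives 2500 nM
- compound 2, `CCn1c(C(=O)NCCCN(C)C)ccc1C(CC)(CC)c1ccc(OCC(O)C(C)(C)C)c(C)c1`: in this assay compound 2 gives 470 nM

Compound 1 stands at the higher of the two numbers measured in this assay, so it is the weaker inhibitor of the pair; compound 2 sits closest, reached by a 5.3-fold lower number from compound 1 to compound 2 (0.73 log units; beyond the scatter). That step changed only the amine at the end of the side chain, (dimethylamino)methyl in place of diethylamino on a saturated chain carbon, two bonds along the chain from an amide-type nitrogen.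

Compound 3, `CCn1c(C(=O)Oc2ccc(CCO)cc2)ccc1C(CC)(CC)c1ccc(OCC(O)C(C)(C)C)c(C)c1`, departs from compound 1 in a different way: a group of 10 heavy atoms (8 carbon, 2 oxygen; one six-membered aromatic ring of carbon only) in place of a group of 8 heavy atoms (6 carbon, 2 nitrogen; no ring), on a carbonyl carbon. The whole (2-(diethylamino)ethyl)amino group leaves and an oxygen-linked aromatic group with a hydroxyethyl chain enters on the same carbonyl carbon. Going by the values given here, no measured step exchanges this part of the molecule, so the single known step, from compound 1 to compound 2, does not bear directly on it and gives no direction to lean on. The expectation is therefore a step of a 1.2-fold higher number from compound 1 to compound 3 (0.08 log units; within the scatter), most likely none beyond the scatter, and compound 3 is estimated at 3000 nM, with a range from 800 nM to 12000 nM.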

Compound 3, half-maximal inhibitory concentration: 22700 nM
Compound 3: the middle estimate sits 7.6-fold (0.88 log units) below what was measured, outside the stated range (above it).
By their numbers in this assay, from the lowest: compound 2; then compound 1; then compound 3.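

Going by these compounds alone, compound 1 and compound 2 differ only at the far end of the side chain, whereas compound 3 is the first to lose the whole (2-(diethylamino)ethyl)amino group on the carbonyl carbon, and in this assay this exchange for an oxygen-linked aromatic group with a hydroxyethyl chain gives a 9.1-fold higher number from compound 1 to compound 3 (0.96 log units; beyond the scatter). Measured against the other side chain, the same kind of exchange gives a 48-fold higher number from compound 2 to compound 3 (1.68 log units; beyond the scatter), so both amine-bearing compounds sit at lower numbers than compound 3, and changes on this carbonyl carbon can move the number further than the earlier swap at the chain end did. Nothing available explains why the number moves at this position.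

The exchange alters several things at once: the amine goes, an oxygen takes the place of the amide-type nitrogen, and an aromatic ring and a hydroxyethyl chain arrive, so the compounds shown cannot say which of these carries the step. Also open, on these data alone, is how a 2-(diethylamino)ethoxy group or a plain anilino group on the same carbonyl carbon would read, since either would separate these parts.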